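Amide to Acid on a Shared Core: Expected Exposure

The source may report more compounds than this note shows. Statements on the series, on what has been measured and on what is new or still open speak of the compounds shown alone.

The measured compounds and their values:
compound 1 `COc1ccc2nc(COc3ccc(CC(SC)C(N)=O)cc3)n(C)c2c1` gives 2.71 ng.h/mL
compound 2 `COc1ccc2nc(COc3ccc(CC(C(N)=O)S(C)(=O)=O)cc3)n(C)c2c1` gives 9.85 ng.h/mL
compound 3 `Cn1c(COc2ccc(CC3SC(=O)NC3=O)cc2)nc2ccc(O)cc21` gives 280 ng.h/mL

These were read in an ADME assay on the whole organism (plasma, strain F344/DuCrlCrlj) for pharmacokinetics, with Rattus norvegicus as the target, read by LC-MS, at a dose of 1 mg/kg by the oral route; a higher number here means more compound in the circulation at the dose given, a lower number less compound in the circulation. Within the data shown here, compound 1 stands lowest of the three: compound 2 lies nearest, and the one measured step that covers this pair, a 3.6-fold higher number from compound 1 to compound 2 (0.56 log units; beyond the scatter), is a modest rise. Compound 3 stands furthest from compound 1, far above it.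

Compound 4 `COc1ccc2nc(COc3ccc(CC(SC)C(=O)O)cc3)n(C)c2c1` is not yet measured. It differs from compound 1 in one place: hydroxy in place of amino on a carbonyl carbon. Among the measured compounds shown here, no measured step covers this kind of change; the only step available swaps a methylsulfanyl for a methylsulfonyl, a different part of the molecule, and so says nothing direct about the amide-to-acid change. With no guide among the measured steps, the expectation for compound 4 rests on compound 1 alone, and the step of a 1.8-fold higher number from compound 1 to compound 4 (0.27 log units; within the scatter) is estimated to stay close to the scatter, with no firm direction. Compound 4 is thus expected to give about 5 ng.h/mL, with a range from 1 ng.h/mL to 25 ng.h/mL.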

Compound 4, area under the concentration-time curve: 3.29 ng.h/mL
Estimate against measurement, compound 4: 1.5-fold (0.18 log units) above, within the range that was stated.
By their numbers in this assay, from the lowest: compounds 1 and 4 (each within the scatter of the next); then compound 2; then compound 3.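

In this assay, the change from carbamoyl to carboxy with the methylsulfanyl group kept gives a 1.2-fold higher number from compound 1 to compound 4 (0.08 log units; within the scatter), so this swap on the carbonyl carbon does not separate the two compounds. The wider replacement of carbamoyl(methylsulfonyl)methyl by carboxy(methylsulfanyl)methyl, which changes the sulfur group as well, gives a 3.0-fold lower number from compound 2 to compound 4 (0.48 log units; beyond the scatter), a step of similar size to a 3.6-fold higher number from compound 1 to compound 2 (0.56 log units; beyond the scatter), where only the sulfur group changes. No measurement shown gives a reason for either new step.

The compounds shown leave open whether hydroxy in place of amino would read the same with methylsulfonyl on the chain, since the carboxy group appears here only with methylsulfanyl. They also leave open how a methyl ester on that carbonyl carbon would read.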